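Methoxy Additions on an Aminochalcone Scaffold

A few compounds are considered here, and "the series" means these few. Any claim that something is new, unique, unknown or untested is made for them only; others in the source may bear on it.

The measured compounds are:
compound 1 `Nc1ccc(/C=C/C(=O)c2ccccc2)cc1` with 36000 nM;
compound 2 `COc1ccc(C(=O)/C=C/c2ccc(N)cc2)cc1` with 98000 nM;
compound 3 `COc1cccc(/C=C/C(=O)c2ccc(N)cc2)c1` with 19000 nM.

All three were tested in a functional assay on HeLa cells (Homo sapiens) for antiproliferative activity, with a stated time of 48 h; on this read-out lower numbers stand for stronger inhibition and higher numbers for weaker inhibition. Compound 1 gives 36000 nM, and the step to compound 2 is a 2.7-fold higher number from compound 1 to compound 2 (0.43 log units; beyond the scatter), where the change is methoxy in place of hydrogen on an aromatic carbon. Compound 3, the compound with the lowest number of the three, gives 19000 nM; its difference from compound 1 is within the usual scatter, while compound 2 stands well beyond it. How the cores of compound 1 and compound 3 differ is not broken down here.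

The unmeasured compound 4 `COc1cc(/C=C/C(=O)c2ccc(N)cc2)cc(OC)c1` arises from compound 3 by methoxy in place of hydrogen on an aromatic carbon. This is the same kind of change as that from compound 1 to compound 2, but not the same: there the methoxy entered para to a large group, whereas here it enters meta to a large group and meta to a methoxy group, on the other ring of the molecule. In this assay compound 4 is expected to give 20000 nM, with a range from 6000 nM to 60000 nM. Among the compounds with values here, the expected step from compound 3 to compound 4 is a 1.1-fold higher number from compound 3 to compound 4 (0.02 log units; within the scatter), estimated as a small one because the only measured methoxy step, a 2.7-fold higher number from compound 1 to compound 2 (0.43 log units; beyond the scatter), sits at a different place, so little weight is put on its direction. Whether compound 4 follows this expectation is what the measurement will show.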

Compound 4, half-maximal inhibitory concentration: 7900 nM
Beside the measured number, compound 4's estimate is 2.5-fold (0.40 log units) above it; the measured number falls inside the stated range.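

In this assay, the methoxy group that enters meta to a large group and meta to a methoxy group gives a 2.4-fold lower number from compound 3 to compound 4 (0.38 log units; beyond the scatter), so here the added group goes with a lower number, not a higher one. Set beside the earlier methoxy step, this shows that the change does not carry over from one core to the other in this series with the same direction, and the gap between the two steps is larger than repeated measurements would explain: the same change on two cores in this assay, a 2.7-fold higher number (0.43 log units; beyond the scatter) from compound 1 to compound 2 and a 2.4-fold lower number (0.38 log units; beyond the scatter) from compound 3 to compound 4, 6.5-fold (0.82 log units) apart, beyond the scatter of two such steps What this does not show is why the two steps part, since they differ both in the core and in the place where the methoxy group enters, and a single pair of steps cannot separate these two differences or support a general rule for the series.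

The compounds shown leave open how the same methoxy change would act at one fixed place on both cores, which would separate the role of the core from that of the place. They also leave open whether an ethoxy group, a hydroxyl group or a fluorine atom at the place taken in compound 4 would move the number as methoxy does.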